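Guanidinopurine series: larger side chain on the core

This account rests on a few compounds, and the source may have more. Where it says the series, first, only, none or still open, it means among the compounds named here.

Measured compounds in a functional assay on MCF7 cells (Homo sapiens) for inhibition, read by fluorescence, with a stated time of 72 h; on this read-out lower numbers stand for stronger inhibition and higher numbers for weaker inhibition:
Compound 1, `Cn1cnc2c(NC(=N)N)nc(N)nc21`: in this assay compound 1 gives > 100000 nM, which is a limit of the assay and not a number.
Compound 2, `CCCn1cnc2c(NC(=N)N)nc(N)nc21`: in this assay compound 2 gives 36500 nM.
Compound 3, `CC(C)n1cnc2c(NC(=N)N)nc(NCCO)nc21`: in this assay compound 3 gives 12400 nM.

Compound 3 holds the lowest of the two numbers; the nearest number, that of compound 2, stands higher by more than the scatter. Within the data shown here, the only step measured in one place is an at least 2.7-fold lower number from compound 1 to compound 2 (0.43 log units; beyond the scatter), an ethyl in place of hydrogen on a saturated chain carbon bound to an aromatic nitrogen.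

Compound 4, `CC(C)[C@H](N)COc1nc(NC(=N)N)c2ncn(C(C)C)c2n1`, differs from compound 3 by 2-amino-3-methylbutoxy in place of (2-hydroxyethyl)amino on an aromatic carbon. The measured step concerns a different position, so it does not bear directly on this change; the numbers give no direction for it, and the exchange may shift the read-out either way or not beyond the scatter. Compound 4 is therefore expected to give roughly 5000 nM in this assay, between 800 nM and 30000 nM, which amounts to an expected 2.5-fold lower number from compound 3 to compound 4 (0.39 log units; beyond the scatter).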

Compound 4, half-maximal inhibitory concentration: 3400 nM
For compound 4 the middle estimate is 1.5-fold (0.17 log units) above the measured one; measured number inside the range.
By their numbers in this assay, from the lowest: compound 4; then compound 3; then compound 2. At a limit, above all of these: compound 1.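

The position on the aromatic carbon between two ring nitrogen atoms now has a measured step of its own, whereas the earlier step concerned only the chain on the ring nitrogen. In this assay, 2-amino-3-methylbutoxy in place of (2-hydroxyethyl)amino gives a 3.6-fold lower number from compound 3 to compound 4 (0.56 log units; beyond the scatter), so this position can move the read-out beyond the scatter, and in this one pair the larger group, with 7 heavy atoms against 4 and a defined stereocentre, goes with the lower number. Nothing at hand accounts for this step.

Which part of the entering group goes with the lower number stays open, as the single exchange alters the linking atom, the chain and the stereocentre together. A 2-amino-3-methylbutylamino group at this position, or the opposite configuration of the 2-amino-3-methylbutoxy group, would begin to separate these.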